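Working notes: from compound 2 to compound 4

A few compounds are considered here, and "the series" means these few. Any claim that something is new, unique, unknown or untested is made for them only; others in the source may bear on it.

In an ADME assay on CCRF-CEM cells (Homo sapiens) for cytotoxicity, with a stated time of 4 days (a lower number here means that less compound is tolerated, a higher number that more compound is tolerated), compound 1 `Cc1cn([C@@H]2O[C@H](CO[Si](C)(C)C(C)(C)C)[C@@]3(OS(=O)(=O)C=C3N)[C@H]2O[Si](C)(C)C(C)(C)C)c(=O)n(C(=O)OC(C)(C)C)c1=O` gives 26000 nM, compound 2 `Cc1cn([C@@H]2O[C@H](CO[Si](C)(C)C(C)(C)C)[C@@]3(OS(=O)(=O)C=C3N)[C@H]2O[Si](C)(C)C(C)(C)C)c(=O)n(C(=O)C2CC2)c1=O` gives 11000 nM, and compound 3 `Cc1cn([C@@H]2O[C@H](CO[Si](C)(C)C(C)(C)C)[C@@]3(OS(=O)(=O)C=C3N)[C@H]2O[Si](C)(C)C(C)(C)C)c(=O)n(C(=O)CCCC(=O)N(C)C)c1=O` gives 9500 nM. Compound 2 therefore lies well under compound 1 and level with compound 3 within the scatter. Compound 4 `CSC(=O)CCCC(=O)n1c(=O)c(C)cn([C@@H]2O[C@H](CO[Si](C)(C)C(C)(C)C)[C@@]3(OS(=O)(=O)C=C3N)[C@H]2O[Si](C)(C)C(C)(C)C)c1=O` differs from compound 2 by 3-((methylsulfanyl)carbonyl)propyl in place of cyclopropyl on a carbonyl carbon. Going by the values given here, the closest precedent is a 1.2-fold lower number from compound 2 to compound 3 (0.06 log units; within the scatter), where a chain without a ring also replaces cyclopropyl on a carbonyl carbon. The larger steps, a 2.4-fold lower number from compound 1 to compound 2 (0.37 log units; beyond the scatter) and a 2.7-fold lower number from compound 1 to compound 3 (0.44 log units; beyond the scatter), both start from tert-butoxy and bear on this change less directly. The expected result is a 1.1-fold lower number from compound 2 to compound 4 (0.04 log units; within the scatter), with no change beyond the scatter. Compound 4 is estimated at 10000 nM, within a range of 4500 nM to 22000 nM.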

Compound 4, half-maximal cytotoxic concentration: 9900 nM
Estimate against measurement, compound 4: 1.0-fold (0.00 log units) above, and the stated range covers the measured number.
By their numbers in this assay, from the lowest: compounds 3, 4 and 2 (each within the scatter of the next); then compound 1.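

In this assay, the 3-((methylsulfanyl)carbonyl)propyl chain on a carbonyl carbon stays level with the cyclopropyl group, with a 1.1-fold lower number from compound 2 to compound 4 (0.05 log units; within the scatter), so a second chain without a ring fits this position without a change beyond the scatter. The end group of the chain also makes no difference that can be read here, with a 1.0-fold higher number from compound 3 to compound 4 (0.02 log units; within the scatter), while tert-butoxy remains apart, with a 2.6-fold lower number from compound 1 to compound 4 (0.42 log units; beyond the scatter). No supporting data explain these numbers.

Going by these compounds, whether an amine, a carboxylic acid or a longer chain on this carbonyl carbon would stay level with compound 2 remains open.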